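The source may hold more compounds than are shown below. What is called first, only, known or untested is meant among the compounds shown, and "the series" means these compounds.

Among the compounds with values here, in a functional assay on NCI/ADR-RES cells (Homo sapiens) for antiproliferative activity, read by luminescence and CellTiter-Glo, with a stated time of 4 days (a higher number here means a weaker inhibitor of growth, a lower number a stronger inhibitor of growth), compound 1 `COc1ccc(-c2nsc3c2NC(=O)CC3c2cccc(OC)c2)cc1` gives 420 nM and compound 2 `COc1ccc(-c2nsc3c2NC(=O)CC3c2cccc(Cl)c2)cc1` gives 562 nM, so compound 2 lies within the scatter of the only other measured compound. Compound 3 `COc1ccc(-c2nsc3c2NC(=O)CC3c2cccc(F)c2)cc1` differs from compound 2 in one place: fluoro in place of chloro on an aromatic carbon. This is fluoro in place of chloro on an aromatic carbon. Within the data shown here, the one measured step on that same carbon, chloro in place of methoxy, is a 1.3-fold higher number from compound 1 to compound 2 (0.13 log units; within the scatter). Among the measured compounds shown here, with only this step as a guide, no change beyond the scatter is expected in this assay, in either direction. The expected step is a 1.1-fold lower number from compound 2 to compound 3 (0.05 log units; within the scatter). For compound 3 the estimate is 500 nM, with an expected range of 250 nM to 1000 nM.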

Compound 3, concentration for 50% growth inhibition: 2960 nM
Compound 3: the middle estimate sits 5.9-fold (0.77 log units) below what was measured, and the stated range ends below it.
By their numbers in this assay, from the lowest: compounds 1 and 2 (each within the scatter of the next); then compound 3.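

In this assay, fluoro in place of chloro gives a 5.3-fold higher number from compound 2 to compound 3 (0.72 log units; beyond the scatter) and fluoro in place of methoxy gives a 7.0-fold higher number from compound 1 to compound 3 (0.85 log units; beyond the scatter) on this aromatic carbon. The position therefore does respond to the group it carries, even though methoxy and chloro read alike, and compound 3 is the weakest inhibitor of growth of the three. Nothing available explains why fluoro stands apart. As far as these compounds go, whether plain hydrogen, a methyl or an amine on this carbon would read like fluoro or like the other two remains open. Three groups are too few to establish a trend.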